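Cyclopentyl amide on a shared core: an expectation

A few compounds are considered here, and "the series" means these few. Any claim that something is new, unique, unknown or untested is made for them only; others in the source may bear on it.

In a functional assay on MCF7 cells (Homo sapiens) for inhibition, read by MTT assay, with a stated time of 72 h (on this read-out higher numbers stand for weaker inhibition and lower numbers for stronger inhibition), compound 1 `CC(C)n1ncc2c(C(=O)Nc3ccccc3)cccc21` gives 19700 nM. Compound 2 `CC(C)n1ncc2c(C(=O)Nc3cccnc3)cccc21` differs from it only in the group on the amide-type nitrogen. In this assay compound 2 reaches only the limit of the measurement, > 40000 nM, so its exact number is not known. For the measured compounds named here, the one measured step is an at least 2.0-fold higher number from compound 1 to compound 2 (0.30 log units; that floor lies within the scatter); its end point is the limit of > 40000 nM in this assay, at which 1 of the 2 values shown sits. Compound 3 `CC(C)n1ncc2c(C(=O)NC3CCCC3)cccc21` is not yet measured, and the change from compound 2 to compound 3 is cyclopentyl in place of pyridin-3-yl on an amide-type nitrogen. Going by the values given here, no measured step covers a non-aromatic ring on this nitrogen, so the expectation rests only on the two values shown, one a number and one a limit. Compound 3 is therefore expected to stay near the weak end of what has been seen, with an at least 1.1-fold lower number from compound 2 to compound 3 (0.05 log units; that floor lies within the scatter) as the estimated step. In this assay compound 3 is estimated at 35000 nM, with a range from 12000 nM to 100000 nM.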

Compound 3, half-maximal inhibitory concentration: > 40000 nM
Compound 3: no number, only a limit; the forecaster's own chance of this, stated with the estimate: 55%; middle value at least 1.1-fold (0.05 log units) away from the limit.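

In this assay compound 3 gives > 40000 nM, which is a limit of the assay and not a number. Cyclopentyl, a non-aromatic ring of carbon only, now joins pyridin-3-yl at this limit on the amide-type nitrogen, so phenyl in compound 1 remains the only group shown here with a readable number: the limit of > 40000 nM in this assay, at which 2 of the 3 values shown sit. Replacing phenyl with cyclopentyl gives an at least 2.0-fold higher number from compound 1 to compound 3 (0.30 log units; that floor lies within the scatter), while the step between the two limits cannot be read.

On these data alone, how far compound 2 and compound 3 lie beyond the limit stays open. Also open, as far as these compounds go, is whether a benzyl group or a chlorophenyl ring on this nitrogen would give a lower number than compound 1 with 19700 nM.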